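The source may report more compounds than this note shows. Statements on the series, on what has been measured and on what is new or still open speak of the compounds shown alone.

Measured so far: compound 1 `CC(C)(C)Cc1c(-c2ccccc2)sc(N)c1C(=O)c1cccc(Cl)c1` with 2% in an assay on CHO cells for displacement of a labelled ligand from adenosine receptor A1 (Homo sapiens), read by scintillation counting, tested at 10 uM; on this read-out higher numbers stand for more inhibition at the one concentration tested (going by the name of the read-out) and lower numbers for less inhibition; compound 2 `CC(C)(C)Cc1c(-c2ccccc2)sc(N)c1C(=O)c1ccc(Cl)c(Cl)c1` with 1% in this assay.

Compound 2 is the lowest of the two numbers shown, but its nearest neighbour, compound 1, sits within the scatter: a number 1 percentage points lower from compound 1 to compound 2 (within the scatter), so the two read as alike.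

Compound 3 `Cc1ccc(C(=O)c2c(N)sc(-c3ccccc3)c2CC(C)(C)C)cc1` is not yet measured. It differs from compound 2 in one place: 4-methylphenyl in place of 3,4-dichlorophenyl on a carbonyl carbon.

Within the data shown here, only one measured step bears on this change, and only loosely: a number 1 percentage points lower from compound 1 to compound 2 (within the scatter) covers one chloro on the same ring and stays within the scatter. Among the measured compounds shown here, there is no measured step for a methyl on that ring or for removal of both chlorines, so the expectation rests on the flatness of compounds 1 and 2. No step beyond the scatter is therefore expected in this assay for compound 3, and the estimated step is a number 1 percentage points higher from compound 2 to compound 3 (within the scatter).

Compound 3 is estimated at 2%, with a range from -8% to 12%.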

Compound 3, a percentage reported as inhibition, at one concentration (the size of the read-out at that concentration, not a potency): 1%
Compound 3: the middle estimate sits 1 percentage points above what was measured; the measured number falls inside the stated range.
By their numbers in this assay, from the lowest: compounds 2, 3 and 1 (each within the scatter of the next).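

On the carbonyl carbon, the aryl group can lose all its chlorine and carry a methyl instead without leaving the scatter in this assay: 4-methylphenyl in place of 3,4-dichlorophenyl gives (no change at the digits printed from compound 2 to compound 3 (within the scatter)), and 4-methylphenyl in place of 3-chlorophenyl gives (a number 1 percentage points lower from compound 1 to compound 3 (within the scatter)). The three aryl groups at this place therefore read as alike, and this change does not separate the compounds in this assay. No evidence is at hand on what lies behind this flat result.

Still open, as far as these compounds go, is whether an amine or a carboxylic acid in place of the methyl of compound 3 would lift the number beyond the scatter. Also open, from the compounds shown here alone, is whether a change elsewhere on the shared core, such as a longer chain, would move the number at all.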